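Lengthening the Chain End of Compound 2

The source may hold more compounds than are shown below. What is called first, only, known or untested is meant among the compounds shown, and "the series" means these compounds.

In a functional assay on SK-MEL-2 cells (Homo sapiens) for cytotoxicity (a lower number here means that less compound is needed, a higher number that more compound is needed for the effect), compound 1 `C=CCCCCCC#CC#CCO` gives 9.56 ug/mL, while compound 2 `C=CCCCCCC#CC#CC(O)CC(C)=O` gives 3.74 ug/mL, the lowest of the two numbers, reached by a 2.6-fold lower number from compound 1 to compound 2 (0.41 log units; beyond the scatter). Compound 3 `C=CCCCCCCCC#CC#CC(O)CC(C)=O` has not yet been measured. It differs from compound 2 in a single place: but-3-en-1-yl in place of vinyl on a saturated chain carbon, five bonds along the chain from a triple-bonded carbon. Among the measured compounds shown here, no measured step bears on this kind of change: the only step known, the one that separates compound 1 from compound 2, concerned the addition of a 2-oxopropyl group and tells nothing about extending the chain end from vinyl to but-3-en-1-yl. Without any guide from the measured pair, the expected step of a 1.1-fold lower number from compound 2 to compound 3 (0.03 log units; within the scatter) is none beyond the scatter. Compound 3 is therefore estimated to give 3.5 ug/mL, with a plausible range of 1.5 ug/mL to 8 ug/mL, in this assay.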

Compound 3, concentration for half-maximal effect: 3.52 ug/mL
Compound 3: the middle estimate sits 1.0-fold (0.00 log units) below what was measured; the measured number falls inside the stated range.
By their numbers in this assay, from the lowest: compounds 3 and 2 (each within the scatter of the next); then compound 1.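

The change from vinyl to but-3-en-1-yl is the first one shown at this saturated chain carbon, five bonds along the chain from a triple-bonded carbon, and in this assay it gives a 1.1-fold lower number from compound 2 to compound 3 (0.03 log units; within the scatter). At this place, then, a group of 4 carbon atoms can stand in place of one of 2 without a measurable change in the number, so the value reached with the 2-oxopropyl group of compound 2 is kept in compound 3. Nothing measured here offers a reason for this result.

As far as these compounds go, it remains open whether a longer chain, such as hex-5-en-1-yl, would also leave the number unchanged. Also open, from the compounds shown here alone, is what a saturated butyl group, an amine or a carboxylic acid would do at this place.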